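The source may report more compounds than this note shows. Statements on the series, on what has been measured and on what is new or still open speak of the compounds shown alone.

Compound 1, `Cc1ccc([C@H](C)NC(=O)Cn2nnc3ccccc3c2=O)cc1`, gives < 9.9 mL/min/kg. Compound 2, `COc1ccc([C@H](C)NC(=O)Cn2nnc3ccccc3c2=O)cc1`, gives 13 mL/min/kg. Compound 3, `COc1ccc([C@H](C)NC(=O)Cn2nnc3ccccc3c2=O)c(OC)c1`, gives 24 mL/min/kg.

These three compounds were run in an ADME assay on microsomes from liver (Homo sapiens) for metabolic stability; a lower number here means slower removal, a higher number faster removal of the compound. For compound 1 only the limit of < 9.9 mL/min/kg in this assay, at which 1 of the 3 values shown sits, is known, so this is a limit of the assay and not a number. The core of compound 1 differs from that of compound 2 by methyl in place of methoxy on an aromatic carbon, and the step of an at least 1.3-fold higher number from compound 1 to compound 2 (0.11 log units; that floor lies within the scatter). Within the core of compound 2, the change methoxy in place of hydrogen on an aromatic carbon gave the step of a 1.8-fold higher number from compound 2 to compound 3 (0.27 log units; within the scatter).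

Compound 4, `COc1cccc2nnn(CC(=O)N[C@@H](C)c3ccc(C)cc3)c(=O)c12`, has not yet been measured in this assay. It differs from compound 1 by methoxy in place of hydrogen on an aromatic carbon. Among the compounds with values here, this is the same kind of change as the one from compound 2 to compound 3, but not the same: there the place was ortho to a large group and meta to a methoxy group, whereas here it is part of a fused or bridged system of two rings, ortho to a fused ring and meta to a fused ring. Resting on the measured step of a 1.8-fold higher number from compound 2 to compound 3 (0.27 log units; within the scatter), the step of an at least 1.4-fold higher number from compound 1 to compound 4 (0.15 log units; that floor lies within the scatter) is expected for compound 4. For compound 4 a value of 14 mL/min/kg is estimated, with a range from 7 mL/min/kg to 28 mL/min/kg.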

Compound 4, clearance in the Homo sapiens assay: 48 mL/min/kg
Beside the measured number, compound 4's estimate is 3.4-fold (0.54 log units) below it; the whole stated range lies below it.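

In the Homo sapiens assay, methoxy in place of hydrogen on an aromatic carbon, at a place ortho to a fused ring and meta to a fused ring, gave an at least 4.8-fold higher number from compound 1 to compound 4 (0.68 log units; beyond the scatter), while in a physicochemical assay for solubility, read by HPLC, in phosphate buffer, with a stated time of 16 h, at pH 6.8 (a higher number here means a more soluble compound, a lower number a less soluble compound), the same change gave a 1.3-fold lower number from compound 1 to compound 4 (0.11 log units; within the scatter). In the physicochemical assay compound 1 gives 12000 nM and compound 4 gives 9300 nM. This shows that the change can move clearance beyond the scatter on the core of compound 1, but the methoxy enters at a different place in each of the two steps, and their sizes do not settle whether the effect carries from one core to another: the same change on two cores in the Homo sapiens assay, a 1.8-fold higher number (0.27 log units; within the scatter) from compound 2 to compound 3 and an at least 4.8-fold higher number (0.68 log units; beyond the scatter) from compound 1 to compound 4; the limit leaves it open whether they differ. Going by these compounds, compound 1 stands at a limit and not at a number, so the true size of its step stays unknown: the limit of < 9.9 mL/min/kg in the Homo sapiens assay, at which 1 of the 4 values shown sits.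

The compounds shown leave open whether the same methoxy at this place would give a step of like size on the core of compound 2. They also leave open what a fluorine, a hydroxyl or an amine at this place on the core of compound 1 would do to clearance.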